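Phenyl for Methyl on the Core of Compound 1

The source may hold more compounds than are shown below. What is called first, only, known or untested is meant among the compounds shown, and "the series" means these compounds.

Compound 1 `Cc1ccc(-c2c(S(=O)(=O)c3ccccc3)cnc3cc(C)nn23)cc1`: 25.8%
Compound 2 `Cc1ccc(-c2c(S(=O)(=O)c3ccccc3)cnc3ncnn23)cc1`: 7.5%
Compound 3 `Cc1cc2ncc(S(=O)(=O)c3ccccc3)c(-c3ccc(Br)cc3)n2n1`: 7.4%

In a functional assay on the whole organism for inhibition, with Mus musculus as the target, with a stated time of 1 h, at a dose of 50 mg/kg by the oral route (on this read-out lower numbers stand for less inhibition and higher numbers for more inhibition at the one dose given (going by the name of the read-out)), compound 1 stands highest of the three measured compounds, beyond the scatter above both compound 2 and compound 3. Compound 4 `Cc1ccc(-c2c(S(=O)(=O)c3ccccc3)cnc3cc(-c4ccccc4)nn23)cc1` differs from compound 1 by phenyl in place of methyl on an aromatic carbon. For the measured compounds named here, the one measured step, a number 18.4 percentage points lower from compound 1 to compound 3 (beyond the scatter), swaps a group at a different place of the molecule, so no measured step bears directly on this change. With nothing to point a direction, the expectation stays near the number of compound 1, with a wide range. The estimated step is a number 5.8 percentage points lower from compound 1 to compound 4 (within the scatter). Compound 4 is expected to give 20% in this assay, with an estimated range from 0% to 40%.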

Compound 4, a percentage reported as inhibition, in the whole organism at one dose (the size of the read-out at that dose, not a potency): 42.5%
The estimate for compound 4 lay 22.5 percentage points below the measured number; the whole stated range lies below it.
By their numbers in this assay, from the lowest: compounds 3 and 2 (each within the scatter of the next); then compound 1; then compound 4.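

In this assay, this carbon of the five-membered ring carries a far larger group than methyl without any loss: phenyl brings a number 16.7 percentage points higher from compound 1 to compound 4 (beyond the scatter). For the compounds shown here, this is the first measured change at this position, and it shows that an added aromatic ring of carbon only can raise the number at this one dose. No measured evidence bears on the reason for this rise.

Going by these compounds, whether the ring itself matters or mere size is enough stays open, and an ethyl chain or an amine at this carbon would help to separate the two. Also open, on these data alone, is whether phenyl gives a similar step alongside the bromo group of compound 3.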